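Cyclohexyl for 3-ethylphenyl on the amide nitrogen of compound 1

This account rests on a few compounds, and the source may have more. Where it says the series, first, only, none or still open, it means among the compounds named here.

Three compounds of the series have numbers in a functional assay on HEK293 cells for agonist activity at D(4) dopamine receptor (Homo sapiens), read by FLIPR; a higher number here means that more compound is needed for the effect, a lower number that less compound is needed. Compound 1 `CCc1cccc(NC(=O)CN2CCC(c3cccc[n+]3[O-])CC2)c1` gives 95 nM in this assay. Compound 2 `Cc1cccc(NC(=O)CN2CCC(c3nccs3)CC2)c1` gives 1 nM, and compound 3 `COc1cccc(C)c1NC(=O)CN1CCC(c2cccc[n+]2[O-])CC1` gives 340 nM. Compound 1 thus stands second highest of the three: compound 3 lies above it by a margin beyond the scatter, while compound 2 lies far below it, also beyond the scatter. Among the compounds with values here, no two of these three differ in only one place, so no single-point step is available as a guide.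

Compound 4 `O=C(CN1CCC(c2cccc[n+]2[O-])CC1)NC1CCCCC1` is not yet measured. It differs from compound 1 in one place: cyclohexyl in place of 3-ethylphenyl on an amide-type nitrogen. The shared core and the group on the piperidine are unchanged. Within the data shown here, because compound 1 sits at 95 nM and no measured pair isolates the effect of exchanging an aromatic ring for a saturated one at this position, the direction of the step is open; a moderate rise in the number, beyond the scatter but not large, is expected rather than a gain. The expected step from compound 1 to compound 4 is a 2.6-fold higher number from compound 1 to compound 4 (0.42 log units; beyond the scatter). Compound 4 is therefore estimated at 250 nM in this assay, with a range from 60 nM to 1000 nM.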

Compound 4, half-maximal effective concentration: 294 nM
For compound 4 the middle estimate is 1.2-fold (0.07 log units) below the measured one; low and high end bracket the measured number.
By their numbers in this assay, from the lowest: compound 2; then compound 1; then compounds 4 and 3 (each within the scatter of the next).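

Within the data shown here, this is the first comparison that changes a single place: in this assay, cyclohexyl in place of 3-ethylphenyl on the amide-type nitrogen gives a 3.1-fold higher number from compound 1 to compound 4 (0.49 log units; beyond the scatter). With the rest of compound 1 held fixed, an aromatic ring on this nitrogen is therefore not required for agonist activity, although the saturated ring needs more compound for the effect. No available data bear on the origin of this step.

The step merges two changes, the loss of the aromatic ring and the loss of the ethyl group, and their shares cannot be separated here; an unsubstituted phenyl or a 3-ethylcyclohexyl group on the same nitrogen would divide them. Also open, from the compounds shown here alone, is whether the same exchange gives a step of similar size on the scaffold of compound 2, which sits far lower at 1 nM but differs from compound 1 in more than one place, and whether a cyclopentyl ring or an open n-butyl chain is accepted on this nitrogen.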